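Swapping Butyl for Trifluoromethyl on the Urea Aryl Ring

The source may report more compounds than this note shows. Statements on the series, on what has been measured and on what is new or still open speak of the compounds shown alone.

In a functional assay on HEK293 cells for antagonist activity at transient receptor potential cation channel subfamily V member 1 (Rattus norvegicus) (a higher number here means a weaker inhibitor, a lower number a stronger inhibitor), compound 3 `CCCCc1ccc(NC(=O)N2CCN(c3ncccc3Cl)CC2)cc1` gives 203 nM. Among the three measured compounds it holds the second-highest number: compound 1 `O=C(Nc1ccc(Oc2ccccc2)cc1)N1CCN(c2ncccc2C(F)(F)F)CC1` gives 916 nM, and compound 2 `CC(C)c1ccc(NC(=O)N2CCN(c3ncccc3Cl)CC2)cc1` gives 17.3 nM. Compound 4 `O=C(Nc1ccc(C(F)(F)F)cc1)N1CCN(c2ncccc2Cl)CC1` differs from compound 3 in one place: trifluoromethyl in place of butyl on an aromatic carbon. For the measured compounds named here, only one measured step bears on this exchange, a 12-fold higher number from compound 2 to compound 3 (1.07 log units; beyond the scatter), and it shows that what sits at this position can move the number far beyond the scatter. Since the butyl chain carries the higher number in that pair, its replacement is expected to lower the number, and the estimated step is a 6.8-fold lower number from compound 3 to compound 4 (0.83 log units; beyond the scatter). Compound 4 is therefore expected to give about 30 nM, within a range from 8 nM to 120 nM.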

Compound 4, half-maximal inhibitory concentration: 81.4 nM
Beside the measured number, compound 4's estimate is 2.7-fold (0.43 log units) below it; low and high end bracket the measured number.
By their numbers in this assay, from the lowest: compound 2; then compound 4; then compound 3; then compound 1.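

In this assay, trifluoromethyl gives a stronger inhibitor than butyl at this position, with a 2.5-fold lower number from compound 3 to compound 4 (0.40 log units; beyond the scatter), but a weaker one than isopropyl, with a 4.7-fold higher number from compound 2 to compound 4 (0.67 log units; beyond the scatter). The three groups on this shared core therefore rank isopropyl, trifluoromethyl, butyl, from lowest number to highest. Butyl and trifluoromethyl have the same heavy-atom count, so that count alone does not set the number here.

Going by these compounds, how an ethyl group, a methoxy group or an amine would compare at this position remains open. Nothing shown here explains the order of these three groups.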